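The source may report more compounds than this note shows. Statements on the series, on what has been measured and on what is new or still open speak of the compounds shown alone.

Measured so far in a functional assay for positive allosteric modulation of GABA-B receptor (Homo sapiens), read by GTPgammaS binding; a higher number here means that more compound is needed for the effect, a lower number that less compound is needed:

compound 1, `Cc1nc(N[C@@H]2C[C@H]3CC[C@@H]2C3)c2cc(-c3ccc(Cl)c(Cl)c3)ccc2n1`: 419 nM
compound 2, `Cc1nc(N[C@@H]2C[C@H]3CC[C@@H]2C3)c2cc(-c3cccc(C(F)(F)F)c3)ccc2n1`: 142 nM
compound 3, `Clc1nc(N[C@@H]2C[C@H]3CC[C@@H]2C3)c2cc(-c3ccc(Cl)c(Cl)c3)ccc2n1`: 341 nM

Compound 1 and compound 3 share a core and differ in one group only: chloro in place of methyl on an aromatic carbon. In this assay the step is a 1.2-fold lower number from compound 1 to compound 3 (0.09 log units; within the scatter), so the exchange of methyl for chloro at that position leaves the number essentially where it was. Compound 2 carries a different pendant aryl group from compound 1; the difference between the two cores is not broken down here. In this assay compound 2 gives the lowest number of the three measured compounds, and its gaps to compound 3 and to compound 1 are both beyond the scatter.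

Compound 4, `FC(F)(F)c1cccc(-c2ccc3nc(Cl)nc(N[C@@H]4C[C@H]5CC[C@@H]4C5)c3c2)c1`, has not yet been measured. It stands to compound 2 as compound 3 stands to compound 1: chloro in place of methyl on an aromatic carbon. The place is described in the same words in both cases, so this is the same change, seen once so far among the measured compounds. For the measured compounds named here, the expected step in this assay from compound 2 to compound 4 is a 1.1-fold lower number from compound 2 to compound 4 (0.06 log units; within the scatter), an expectation that rests on the single precedent a 1.2-fold lower number from compound 1 to compound 3 (0.09 log units; within the scatter), which lay within the scatter. On that basis compound 4 is estimated at 125 nM in this assay, expected to fall between 55 nM and 290 nM.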

Compound 4, half-maximal effective concentration: 90 nM
The estimate for compound 4 lay 1.4-fold (0.14 log units) above the measured number, within the range that was stated.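

In this assay, the exchange of methyl for chloro on the aromatic carbon between two ring nitrogen atoms gives a 1.6-fold lower number from compound 2 to compound 4 (0.20 log units; within the scatter). Set beside the earlier step, the change reads the same on the two cores, which carry different pendant aryl groups: the same change on two cores in this assay, a 1.2-fold lower number (0.09 log units; within the scatter) from compound 1 to compound 3 and a 1.6-fold lower number (0.20 log units; within the scatter) from compound 2 to compound 4, 1.3-fold (0.11 log units) apart, within the scatter of two such steps. For the compounds shown here, on these two cores, methyl and chloro at that place can therefore be carried across without a step that stands out from the scatter, but this rests on only two pairs, says nothing about cores with other pendant aryl groups or other groups on the exocyclic nitrogen, and does not extend to any other assay or property.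

From the compounds shown here alone, it remains open whether a group other than methyl or chloro at that carbon, such as an amine, a methoxy group or a nitrile, would also leave the number in the same range. Going by these compounds, it also remains open whether the small size of this step would persist if the bicyclic group on the exocyclic nitrogen were replaced by a simple alkyl chain, or if the pendant aryl group were replaced by a pyridine.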